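The compounds below may be only part of what the source reports. "The series", "measured", "known", "first", "only" and "open" are said of these compounds alone.

Within the data shown here, compound 1 `O=c1c(-c2nnc(-c3ccc(Cl)cc3)o2)c[nH]c2ncc(-c3cccnc3)cc12` is the first of two measured compounds in a functional assay on HCT-116 cells (Homo sapiens) for inhibition, read by MTT assay, with a stated time of 24 h, tested at 5 uM (on this read-out higher numbers stand for more inhibition of growth at the one concentration tested and lower numbers for less inhibition of growth), where compound 1 gives 15.9%. Compound 2 `CS(=O)(=O)c1ccc(-c2cnc3[nH]cc(-c4nnc(-c5ccc(Cl)cc5)o4)c(=O)c3c2)cc1` carries a 4-(methylsulfonyl)phenyl in place of the pyridin-3-yl of compound 1 on an aromatic carbon, and in this assay compound 2 gives 16.4%. Among the measured compounds shown here, the only measured step, a number 0.5 percentage points higher from compound 1 to compound 2 (within the scatter), is within the scatter, so the two numbers for compound 2 and compound 1 cannot be told apart; compound 2 simply stands alongside compound 1, with no difference that the measurement can resolve.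

Compound 3 `CS(=O)(=O)c1ccc(-c2cnc3[nH]cc(-c4nnc(-c5ccncc5)o4)c(=O)c3c2)cc1` has not yet been measured. It differs from compound 2 in another part of the molecule: pyridin-4-yl in place of 4-chlorophenyl on an aromatic carbon. For the measured compounds named here, no measured step touches this group, and the one step that exists, a number 0.5 percentage points higher from compound 1 to compound 2 (within the scatter), was within the scatter, so there is nothing to suggest a change beyond the scatter here. The expectation for compound 3 is therefore a step of a number 2.4 percentage points lower from compound 2 to compound 3 (within the scatter), giving an estimated value of 14% for compound 3, with a range from 4% to 28%.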

Compound 3, percent growth inhibition at one concentration: 5.61%
The estimate for compound 3 lay 8.4 percentage points above the measured number; low and high end bracket the measured number.
By their numbers in this assay, from the lowest: compound 3; then compounds 1 and 2 (each within the scatter of the next).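

In this assay, the aromatic ring on the five-membered aromatic ring with 2 nitrogen and 1 oxygen proves to be a place where the read-out responds: pyridin-4-yl in place of 4-chlorophenyl gives a number 10.8 percentage points lower from compound 2 to compound 3 (beyond the scatter). Among these compounds, this is the first change to move the number beyond the usual scatter, whereas the exchange at the other end of the molecule, a number 0.5 percentage points higher from compound 1 to compound 2 (within the scatter), left no difference that could be resolved. The change itself is small on paper, as the chlorine leaves, one ring carbon becomes a ring nitrogen and a single hydrogen-bond acceptor enters, yet nothing available explains why this costs growth inhibition at the one concentration tested.

The chlorine and the ring nitrogen change together in this one step, so the compounds shown cannot say which of the two matters, and a plain phenyl at this place would pull them apart. On these data alone, it also remains open how a quite different group here, such as an amine or a carboxylic acid on the phenyl ring, would fare in this assay.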